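The compounds below may be only part of what the source reports. "The series", "measured", "known", "first", "only" and "open" are said of these compounds alone.

Compound 1, `CCOC(=O)c1cccc(-c2cccs2)c1`, gives 90000 nM in an assay on COS-7 cells for inhibition of patatin-like phospholipase domain-containing protein 2 (Mus musculus); a higher number here means a weaker inhibitor, a lower number a stronger inhibitor.
Compound 2, `CCOC(=O)c1cccc(-c2ccc3c(c2)CCN3)c1`, gives 120000 nM in this assay.
Compound 3, `CCNS(=O)(=O)c1cccc(-c2ccc(OCC)cc2)c1`, gives 200000 nM in this assay.

All three compounds share a pair of linked aromatic rings and differ in the groups hung on them. Compound 3 has the highest of the three numbers in this assay, that is, it shows the weakest inhibition. Against compound 2 the gap is small enough to fall inside the ordinary scatter of repeated measurements, so the two cannot be told apart with confidence. Against compound 1 the gap is a little wider and lies beyond that scatter, so compound 1 is the stronger inhibitor of those two.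

Compound 4, `CCOc1ccc(-c2cccc(C(=O)NC)c2)cc1`, has not been measured. It is built from compound 3 by one change: methylcarbamoyl in place of ethylsulfamoyl on an aromatic carbon. Among the measured compounds shown here, no measured pair here shows exactly this swap, so the size of the step has to be judged from the overall spread of the three numbers, which is narrow. A small step toward stronger inhibition is expected from compound 3 to compound 4, of the size a 1.7-fold lower number from compound 3 to compound 4 (0.22 log units; within the scatter), but it may well stay inside the scatter. For compound 4 the estimated value in this assay is 120000 nM, with a range from 40000 nM to 350000 nM.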

Compound 4, half-maximal inhibitory concentration: > 200000 nM
Compound 4: a limit, no number (the forecaster's own chance of this, stated with the estimate: 20%); middle value at least 1.6-fold (0.22 log units) from the limit.
By their numbers in this assay, from the lowest: compounds 1, 2 and 3 (each within the scatter of the next, the first and the last beyond it).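

Among the compounds shown here, compound 3 and compound 4 are the first pair here that differ in only one place, giving the first direct look at the group on this aromatic carbon, which sits meta to a group of 9 heavy atoms. In this assay compound 4 gives > 200000 nM, which is a limit of the assay and not a number. Putting methylcarbamoyl in place of ethylsulfamoyl gives a number no lower from compound 3 to compound 4 (the limit leaves the size open), so this change brings no gain in inhibition, although the size of the step cannot be read, and the reading for this pair ends at a limit: the limit of > 200000 nM in this assay, at which 1 of the 4 values shown sits.

On these data alone, it remains open whether any group on this carbon can give stronger inhibition, for example a carboxylic acid, an amine, or a longer chain on the amide nitrogen. As far as these compounds go, it is also open how far the ethoxy group on the other ring matters, since a change there, such as a hydroxyl group or a longer chain, would test that part of the molecule on its own.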